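Bromophenyl for Chlorophenyl on a Shared Core

A few compounds are considered here, and "the series" means these few. Any claim that something is new, unique, unknown or untested is made for them only; others in the source may bear on it.

Compound 3 `FC(F)(F)c1ccc(CSc2nc(Nc3ccccc3Cl)c3ccccc3n2)cc1` was tested in a functional assay on HGC-27 cells (Homo sapiens) for cytotoxicity, read by MTT assay, with a stated time of 72 h; on this read-out lower numbers stand for stronger inhibition and higher numbers for weaker inhibition. In this assay compound 3 gives only a limit, > 50000 nM, and no number. The same shared core is found in compound 1 `CCCCCCCCCCCCNc1nc(SCc2ccc(C(F)(F)F)cc2)nc2ccccc12` and compound 2 `CCCCCCCCCCCCCCNc1nc(SCc2ccc(C(F)(F)F)cc2)nc2ccccc12`. In this assay compound 1 gives 38700 nM. Compound 2 in this assay likewise returns a limit, > 50000 nM. Within the data shown here, the one measured step between them is an at least 1.2-fold higher number from compound 1 to compound 2 (0.11 log units; that floor lies within the scatter), a change on a saturated chain rather than on an aryl group; here the limit of > 50000 nM in this assay, at which 2 of the 3 values shown sit, should be kept in mind. Compound 4 `FC(F)(F)c1ccc(CSc2nc(Nc3cccc(Br)c3)c3ccccc3n2)cc1` differs from compound 3 by 3-bromophenyl in place of 2-chlorophenyl on a nitrogen on an aromatic ring. Among the measured compounds shown here, no measured step bears on an exchange of one halogenated phenyl for another, and compound 3 itself sits at the limit, so there is no basis for expecting a shift beyond the scatter in this assay in either direction. The expected step is therefore a step that the limit leaves unreadable from compound 3 to compound 4. Compound 4 is accordingly estimated at 60000 nM, within 20000 nM to 150000 nM, and is expected most likely to be reported again only as a limit.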

Compound 4, half-maximal inhibitory concentration: 18300 nM
Compound 4: the middle estimate sits 3.3-fold (0.52 log units) above what was measured, outside the stated range (below it).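

In this assay, among these compounds, the exchange on the nitrogen gives the first aryl compound with a readable number, as compound 4 gives 18300 nM. The result is an at least 2.7-fold lower number from compound 3 to compound 4 (0.43 log units; beyond the scatter), so an aryl exchange at this position moves the read-out beyond the scatter, whereas the earlier step on the saturated chain showed only a floor within it. That size remains a floor, and the true step may be larger, since the value of compound 3 is a limit and not a number: the limit of > 50000 nM in this assay, at which 2 of the 4 values shown sit.

The 2-chlorophenyl and the 3-bromophenyl differ in both the halogen and its place on the ring, so the compounds shown do not separate these two changes. They also leave open how the read-out would respond to a plain phenyl, or to a nitrile or a carboxylic acid on that ring.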